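The compounds below may be only part of what the source reports. "The series", "measured", "known", "first", "only" and "open" are said of these compounds alone.

In a functional assay on MCF7 cells (Homo sapiens) for inhibition, read by MTT assay, with a stated time of 48 h, tested at 10 uM (a higher number here means more inhibition of growth at the concentration tested, a lower number less inhibition of growth), the measured compounds read as follows

compound 1 `Cc1cc(=O)c2c(O)cc(OCc3ccc(Br)cc3)c([C@H]3CCN(C)C[C@H]3O)c2o1` gives 14%
compound 2 `Cc1cc(=O)c2c(O)cc(OC/C=C/c3ccccc3)c([C@H]3CCN(C)C[C@H]3O)c2o1` gives 7%
compound 3 `Cc1oc2c([C@H]3CCN(C)C[C@H]3O)c(O)cc(O)c2c(=O)c1C(O)c1ccc(Cl)cc1` gives 6%

Compound 3 at 6% lies within the usual scatter of both other compounds, so none of the three can be ranked above another in this assay and all show little inhibition of growth.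

Still to be measured is compound 4 `Cc1oc2c([C@H]3CCN(C)C[C@H]3O)c(O)cc(O)c2c(=O)c1C(O)c1csc([N+](=O)[O-])c1` with 5-nitrothiophen-3-yl in place of 4-chlorophenyl on a saturated chain carbon bound to an aromatic carbon and an oxygen on a saturated carbon. Among the measured compounds shown here, no measured step touches this place. For the measured compounds named here, the only step available, a number 7 percentage points lower from compound 1 to compound 2 (within the scatter) (within the scatter), exchanges a different group elsewhere on the shared core, so it is a loose guide and gives no sign of a large shift. No step beyond the scatter is therefore expected. The expected step is a number 3 percentage points higher from compound 3 to compound 4 (within the scatter) and it stays within the scatter. For compound 4 the estimated value is 9% with an expected range from 0% to 28% when measured.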

Compound 4, percent growth inhibition at one concentration: 20%
For compound 4 the middle estimate is 11 percentage points below the measured one; the range from low to high includes it.
By their numbers in this assay, from the lowest: compounds 3, 2, 1 and 4 (each within the scatter of the next, the first and the last beyond it).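

In this assay, bringing in the 5-nitrothiophen-3-yl group gives a number 14 percentage points higher from compound 3 to compound 4 (beyond the scatter). Among the compounds shown here, this shows that the group held at this place can move the read-out by more than the usual scatter, which the earlier compounds could not show, although the size of the step is modest. The change replaces a six-membered aromatic ring of carbon only with a five-membered aromatic ring with one hetero atom and also brings in a nitro group, and nothing measured here says which part matters or why.

A thiophene ring without the nitro group and a nitrophenyl group would help separate those two parts. From the compounds shown here alone, it also remains open what an amine or a carboxylic acid would do at this place, and whether any group there can go well beyond compound 4 at 20%.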